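The compounds below may be only part of what the source reports. "The series", "measured", "known", "first", "only" and "open" are said of these compounds alone.

Working notes on the series, read in a functional assay on MDA-MB-231 cells (Homo sapiens) for antiproliferative activity, read by MTT assay, with a stated time of 24 h; a lower number here means a stronger inhibitor, a higher number a weaker inhibitor. Compound 1 (`O=C(O)CC(NS(=O)(=O)c1ccc(OC(F)(F)F)cc1)c1ccccc1`) gives > 100000 nM, and this is a limit of the assay, not a number. Going by the values given here, compound 2 (`O=C(O)CC(NC(=O)c1ccc(F)cc1)c1ccc(Cl)cc1Cl`) gives 58300 nM, the only true number so far in this assay. The next compound to be read is compound 3 (`O=C(O)CC(NC(=O)c1cccc(Br)c1)c1ccc(Cl)cc1Cl`), which has not yet been measured. Its structural change from compound 2 is 3-bromophenyl in place of 4-fluorophenyl on a carbonyl carbon. Among the compounds with values here, no measured pair gives the size of such a step, so the expectation starts from compound 2 at 58300 nM, with no shift expected beyond the scatter. The expected step of a 1.3-fold lower number from compound 2 to compound 3 (0.11 log units; within the scatter) is therefore small. For compound 3 the estimated value is 45000 nM, with an expected range of 18000 nM to 100000 nM.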

Compound 3, half-maximal inhibitory concentration: 82500 nM
The estimate for compound 3 lay 1.8-fold (0.26 log units) below the measured number; measured number inside the range.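

In this assay, going by these compounds alone, 3-bromophenyl in place of 4-fluorophenyl on a carbonyl carbon gives the first readable step: a 1.4-fold higher number from compound 2 to compound 3 (0.15 log units; within the scatter). This swap changes both the halogen and its place on the phenyl ring, so neither change can be read alone, and together they do not separate the two groups at this position. Compound 1 stands at a limit of the assay, not a number, and the series is read close to that limit: the limit of > 100000 nM in this assay, at which 1 of the 3 values shown sits.

Steps to compound 1 cannot be read, since it differs from compound 2 and compound 3 in more than one place. Still open, on these data alone, is whether any other group on this carbonyl carbon, such as an aminophenyl or a carboxyphenyl, moves the number beyond the scatter.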